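The compounds below may be only part of what the source reports. "The series", "measured", "known", "first", "only" and "open" are said of these compounds alone.

Measured so far in a functional assay on A375P cells (Homo sapiens) for cytotoxicity, read by MTT assay, with a stated time of 2 days; a lower number here means a stronger inhibitor, a higher number a weaker inhibitor:

compound 1 `Fc1ccc2nc(NCCCCN3CCN(c4cccc(Cl)c4Cl)CC3)nc(NCc3ccco3)c2c1` — 2650 nM
compound 2 `Cc1cccc(N2CCN(CCCCNc3nc(NCc4ccco4)c4cc(F)ccc4n3)CC2)c1C` — 3280 nM

For the measured compounds named here, compound 1 stands at one end of the two numbers, with compound 2 as its only neighbour; the gap a 1.2-fold higher number from compound 1 to compound 2 (0.09 log units; within the scatter) lies within the scatter, so the two numbers cannot be told apart. That one step concerns the aryl group on the piperazine nitrogen, where 2,3-dimethylphenyl replaced 2,3-dichlorophenyl.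

Compound 3 `Clc1cccc(N2CCN(CCCCNc3nc(NCc4ccco4)c4ccccc4n3)CC2)c1Cl` keeps the whole of compound 1 except for one point on the shared core: hydrogen in place of fluoro on an aromatic carbon. The change sits on the fused ring system, not on the piperazine side, and neither measured compound varies at that place. Going by the values given here, no measured step therefore bears on this change, and the series gives no guide to its direction. Among the compounds with values here, with the only recorded step small and unrelated, the working expectation is that removing the fluoro leaves the number close to that of compound 1, a step of a 1.0-fold higher number from compound 1 to compound 3 (0.01 log units; within the scatter) that is not expected to exceed the scatter. Compound 3 is accordingly estimated at 2700 nM, with a range from 1300 nM to 6000 nM in this assay.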

Compound 3, half-maximal inhibitory concentration: 3750 nM
Compound 3: the middle estimate sits 1.4-fold (0.14 log units) below what was measured; the range from low to high includes it.
By their numbers in this assay, from the lowest: compounds 1, 2 and 3 (each within the scatter of the next).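

Within this assay this is the only reading at this aromatic carbon of the shared core, and hydrogen in place of fluoro gives a step (a 1.4-fold higher number from compound 1 to compound 3 (0.15 log units; within the scatter)) that does not separate the two groups. With 2,3-dichlorophenyl held constant, the fluoro is therefore not needed to keep the number in the range of compound 1 on this read-out. This place now resembles the aryl group on the amine nitrogen in a ring, where 2,3-dimethylphenyl in place of 2,3-dichlorophenyl also gives a step within the scatter (a 1.2-fold higher number from compound 1 to compound 2 (0.09 log units; within the scatter)), and no available evidence accounts for either result.

Still open is whether a methoxy group or a nitrile on this aromatic carbon would give a number that can be told apart from that of compound 1, since fluoro and hydrogen are the only groups shown there. Also open, going by these compounds, is whether the two aryl groups would stay indistinguishable with hydrogen on this carbon, and whether a longer chain in place of the present one would shift the number beyond the scatter.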